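This account rests on a few compounds, and the source may have more. Where it says the series, first, only, none or still open, it means among the compounds named here.

Measured so far in a functional assay on A549 cells (Homo sapiens) for cytotoxicity, read by MTT assay, with a stated time of 72 h; a lower number here means a stronger inhibitor, a higher number a weaker inhibitor:

compound 1 `COc1cc(Nc2nc3ccccc3nc2S(=O)(=O)c2ccccc2)cc(OC)c1`: 70 nM
compound 2 `O=S(=O)(c1ccccc1)c1nc2ccccc2nc1Nc1ccc(Cl)cc1`: 30700 nM

Compound 1 gives the lowest of these two numbers. Within the data shown here, the single measured step, a 440-fold higher number from compound 1 to compound 2 (2.64 log units; beyond the scatter), concerns the group on the nitrogen. Compound 3 `COc1cc(Nc2nc3ccccc3nc2S(=O)(=O)c2ccc(F)cc2)cc(OC)c1` instead changes the phenylsulfonyl to (4-fluorophenyl)sulfonyl: fluoro in place of hydrogen on an aromatic carbon. Among the measured compounds shown here, no measured step touches that part of the molecule, so nothing here speaks for a large move, and a step within the scatter seems the most likely outcome. Compound 3 is therefore expected to give about 60 nM in this assay, between 20 nM and 200 nM, which would mean a 1.2-fold lower number from compound 1 to compound 3 (0.07 log units; within the scatter).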

Compound 3, half-maximal inhibitory concentration: 5450 nM
Estimate against measurement, compound 3: 91-fold (1.96 log units) below, outside the stated range (above it).
By their numbers in this assay, from the lowest: compound 1; then compound 3; then compound 2.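

Among these compounds, the phenylsulfonyl part, which no earlier step touched, proves just as sensitive in this assay as the group on the nitrogen. A single fluoro in place of hydrogen on its aromatic carbon gives a 78-fold higher number from compound 1 to compound 3 (1.89 log units; beyond the scatter), so even a one-atom change here can produce a large step. No available evidence explains this result. The compounds shown leave open whether this step is particular to fluoro or would also follow from another group on that carbon. A methyl group or an amine there would help separate those two possibilities.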